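The source may report more compounds than this note shows. Statements on the series, on what has been measured and on what is new or still open speak of the compounds shown alone.

Measured so far in an assay on microsomes from liver for inhibition of sterol O-acyltransferase 1 (Rattus norvegicus); on this read-out higher numbers stand for weaker inhibition and lower numbers for stronger inhibition:
compound 1 `Cc1cccc(-c2nc(SC[C@H]3C[C@@](C)(O)CC(=O)O3)[nH]c2-c2cccc(C)c2)c1.Cc1cccc(-c2nc(SC[C@H]3C[C@](C)(O)CC(=O)O3)[nH]c2-c2cccc(C)c2)c1` gives 64 nM
compound 2 `O=C1CC(O)CC(CSc2nc(-c3ccccc3)c(-c3ccccc3)[nH]2)O1` gives 910 nM

Compound 2 has the higher of the two numbers; compound 1 sits a good way lower, beyond the scatter. The two structures differ in several places at once, so no single step can be read between them, and the gap carries no lesson for any one change.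

Compound 3 `c1ccc(-c2nc(SCCC3OCCCO3)[nH]c2-c2ccccc2)cc1` is not yet measured. Relative to compound 2 it carries a group of 7 heavy atoms (5 carbon, 2 oxygen; one six-membered non-aromatic ring with 2 hetero atoms) in place of a group of 8 heavy atoms (5 carbon, 3 oxygen; one six-membered non-aromatic ring with 1 hetero atom), on a saturated chain carbon bound to a sulfur. Within the data shown here, the lactone carbonyl and the hydroxyl that mark compound 2 are gone, and nothing among the measured compounds shows what a ring of that kind does here.

Among the measured compounds shown here, with no comparable step to lean on, a modest weakening is expected, near the scatter or a little beyond it; the step from compound 2 to compound 3 is estimated at a 1.6-fold higher number from compound 2 to compound 3 (0.22 log units; within the scatter). For compound 3 in this assay the expected value is 1500 nM, within 400 nM to 6000 nM.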

Compound 3, half-maximal inhibitory concentration: 730 nM
The estimate for compound 3 lay 2.1-fold (0.31 log units) above the measured number, within the range that was stated.
By their numbers in this assay, from the lowest: compound 1; then compounds 3 and 2 (each within the scatter of the next).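

At this saturated chain carbon bound to a sulfur, this assay gives a 1.2-fold lower number from compound 2 to compound 3 (0.10 log units; within the scatter) for the exchange of the group of 8 heavy atoms for the group of 7 heavy atoms. Among these compounds, this is the first single-place step, and for this pair the carbonyl and the hydroxyl of compound 2 can be lost, along with the ring that carries them, with no change beyond the scatter. No measurement at hand bears on how either group acts at this place.

Whether the same exchange reads alike on the core of compound 1 stays open, and no single step yet accounts for that compound's separate standing. Also open, on these data alone, is what an amine, a carboxylic acid or a longer chain would give at this place.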